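The compounds below may be only part of what the source reports. "The series", "measured", "known", "first", "only" and "open" are said of these compounds alone.

Within the data shown here, compound 2 `CC(C)n1ncc2c(C(=O)NCc3cn(-c4ccccc4)nn3)cccc21` stands highest of the two numbers measured so far: in a functional assay on PC-3 cells (Homo sapiens) for inhibition, read by MTT assay, with a stated time of 72 h (on this read-out higher numbers stand for weaker inhibition and lower numbers for stronger inhibition), compound 2 gives 26000 nM. Its nearest neighbour, compound 1 `CC(C)n1ncc2c(C(=O)NCc3ccccc3)cccc21`, gives 15200 nM in this assay, a value within the scatter of compound 2, so neither can be called the weaker. Compound 3 `CC(C)n1ncc2c(C(=O)NCc3cn(-c4cccc(Br)c4)nn3)cccc21` carries a single change from compound 2, (bromo in place of hydrogen on an aromatic carbon). Among the measured compounds shown here, no measured pair shows such a change, so the data give no direction. The expected step is a 1.3-fold lower number from compound 2 to compound 3 (0.11 log units; within the scatter), a shift that stays within the scatter of this assay. Compound 3 is therefore estimated at 20000 nM, with a range from 7000 nM to 60000 nM.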

Compound 3, half-maximal inhibitory concentration: 33700 nM
Beside the measured number, compound 3's estimate is 1.7-fold (0.23 log units) below it, and the stated range covers the measured number.
By their numbers in this assay, from the lowest: compounds 1, 2 and 3 (each within the scatter of the next, the first and the last beyond it).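

In this assay, the step for phenyl to 3-bromophenyl is a 1.3-fold higher number from compound 2 to compound 3 (0.11 log units; within the scatter). Among these compounds, this is the first measured change on this aromatic carbon, and bromo in place of hydrogen there gives no difference that can be told from the scatter. No measurement shown bears on this result. The compounds shown leave open whether an amine or a carboxylic acid in place of this bromo would move the number beyond the scatter. They also leave open whether bromo on another carbon of the same ring would do so.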